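Series solubility notes: cyclopropyl to phenyl on the sulfonyl

The compounds below may be only part of what the source reports. "The series", "measured", "known", "first", "only" and "open" are said of these compounds alone.

Measured so far:
compound 1 `O=C(Nc1cccn(Cc2ccccc2)c1=O)c1ccc2c(c1)B(O)OC2` gives 3 ug/mL
compound 2 `O=C(Cc1ccc2c(c1)B(O)OC2)NS(=O)(=O)C1CC1` gives 700 ug/mL

Two compounds have been run in an ADME assay for solubility, in simulated intestinal fluid; on this read-out lower numbers stand for lower solubility and higher numbers for higher solubility. Compound 2 holds the higher of the two numbers. The gap between compound 2 and compound 1 is far beyond the scatter, so the pair shows that the shared core can carry either very low or high solubility depending on what is attached to it. Among the compounds with values here, the two compounds differ in several places at once, so no single-change step has been measured and no step size is on hand to lean on.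

Compound 3 `O=C(Cc1ccc2c(c1)B(O)OC2)NS(=O)(=O)c1ccccc1` is next in line for this assay. Relative to compound 2 the change is phenyl in place of cyclopropyl on a sulfonyl sulfur. Within the data shown here, with no measured step for guidance, the expectation rests on compound 2 alone at 700 ug/mL and on the size of the change: a phenyl in place of a cyclopropyl on the sulfonyl sulfur. In this assay the step is expected to be a 3.5-fold lower number from compound 2 to compound 3 (0.54 log units; beyond the scatter), a modest fall that is expected to leave the number well clear of compound 1. Compound 3 is therefore estimated at 200 ug/mL, with a range from 50 ug/mL to 600 ug/mL.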

Compound 3, solubility: 900 ug/mL
The estimate for compound 3 lay 4.5-fold (0.65 log units) below the measured number, and the stated range ends below it.
By their numbers in this assay, from the lowest: compound 1; then compounds 2 and 3 (each within the scatter of the next).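

In this assay, within the data shown here, phenyl in place of cyclopropyl on a sulfonyl sulfur whose other neighbour is an amide-type nitrogen gives a 1.3-fold higher number from compound 2 to compound 3 (0.11 log units; within the scatter), the first single-change step, and it sets no order between the two compounds. A three-membered non-aromatic ring of 3 heavy atoms thus gives way to a six-membered aromatic ring of 6 heavy atoms with the number staying within the scatter, although this rests on one pair and says nothing yet about other groups at this place. No supporting measurement is on hand to account for this step.

Still open, going by these compounds, is whether the number holds when the group on the sulfonyl sulfur is of another kind, such as a longer alkyl chain, or a phenyl carrying an amine or a carboxylic acid. Also open, on these data alone, is how the number responds to single changes elsewhere on compound 3, such as replacing the amide-type nitrogen's hydrogen with a methyl group or altering the carbon link between the carbonyl and the shared core.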